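From nitro to chloro on the aromatic ring

A few compounds are considered here, and "the series" means these few. Any claim that something is new, unique, unknown or untested is made for them only; others in the source may bear on it.

Measured in a functional assay on HepG2 cells (Homo sapiens) for cytotoxicity, read by MTT assay, with a stated time of 48 h; on this read-out higher numbers stand for weaker inhibition and lower numbers for stronger inhibition:
compound 1 `Cc1ccccc1-c1nnc(SCCn2c([N+](=O)[O-])cnc2C)o1`: 5100 nM
compound 2 `CCOc1ccc(-c2nnc(SCCn3c([N+](=O)[O-])cnc3C)o2)cc1`: 1900 nM
compound 3 `Cc1ncc([N+](=O)[O-])n1CCSc1nnc(-c2ccc([N+](=O)[O-])cc2)o1`: 4100 nM

In this assay compound 3, at 4100 nM, lies within the scatter of compound 1 and beyond the scatter from compound 2. Compound 4 `Cc1ncc([N+](=O)[O-])n1CCSc1nnc(-c2ccc(Cl)cc2)o1` carries chloro in place of nitro on an aromatic carbon, para to a large group: chloro in place of nitro on an aromatic carbon. For the measured compounds named here, the one measured step touching nitro is a 2.2-fold higher number from compound 2 to compound 3 (0.33 log units; beyond the scatter), with nitro in place of ethoxy, and it is modest. Going by the values given here, no measured compound carries chloro, so the direction is uncertain, and no step beyond the scatter is expected in this assay. The expected step is a 1.4-fold lower number from compound 3 to compound 4 (0.14 log units; within the scatter). The estimate for compound 4 is 3000 nM, with an expected range from 1300 nM to 7000 nM.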

Compound 4, half-maximal inhibitory concentration: 7800 nM
For compound 4 the middle estimate is 2.6-fold (0.41 log units) below the measured one; the measured number lies above the stated range.
By their numbers in this assay, from the lowest: compound 2; then compounds 3, 1 and 4 (each within the scatter of the next).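

In this assay, chloro in place of nitro on this aromatic carbon gives a 1.9-fold higher number from compound 3 to compound 4 (0.28 log units; within the scatter), so the two groups are not told apart here. Chloro in place of ethoxy at the same position gives a 4.1-fold higher number from compound 2 to compound 4 (0.61 log units; beyond the scatter), a modest step beyond the scatter, while 4-chlorophenyl in place of 2-methylphenyl gives a 1.5-fold higher number from compound 1 to compound 4 (0.18 log units; within the scatter), which stays within it. Nothing at hand explains these steps.

The compounds shown leave open whether ethoxy's lower number extends to a longer alkoxy chain. They also leave open how an amine or a carboxylic acid would read at this position.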